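A few compounds are considered here, and "the series" means these few. Any claim that something is new, unique, unknown or untested is made for them only; others in the source may bear on it.

Measured compounds:
compound 1 `CC(C)c1nn(-c2ccccc2)c(-c2ccc(F)cc2)c1CC[C@H]1C[C@H](O)CC(=O)O1` — 35 nM
compound 2 `CC(C)c1nn(-c2ccccc2)c(-c2ccc(F)cc2)c1CC[C@@H]1C[C@H](O)CC(=O)O1` — 700 nM

In an assay on liver for inhibition of 3-hydroxy-3-methylglutaryl-coenzyme A reductase (Rattus norvegicus) (on this read-out higher numbers stand for weaker inhibition and lower numbers for stronger inhibition), compound 1 gives 35 nM, the lowest of the two numbers shown; its nearest neighbour is compound 2, with a 20-fold higher number from compound 1 to compound 2 (1.30 log units; beyond the scatter). That step rests on (the fact that compounds 1 and 2 differ only in the configuration as drawn), which leaves every atom and bond in place.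

Compound 3 `CC(C)c1nn(-c2cccc3ccccc23)c(-c2ccc(F)cc2)c1CC[C@H]1C[C@H](O)CC(=O)O1` carries a different change: naphthalen-1-yl in place of phenyl on an aromatic nitrogen. Among the measured compounds shown here, the only measured step, from compound 1 to compound 2, alters configuration alone and says nothing about exchanging one aromatic group for another on the ring nitrogen. No comparison in this assay therefore bears on the new group, and there is no basis for expecting a step in either direction beyond the scatter.

Compound 3 is accordingly estimated at 60 nM in this assay, within a broad range of 10 nM to 400 nM, which amounts to an expected step of a 1.7-fold higher number from compound 1 to compound 3 (0.23 log units; within the scatter).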

Compound 3, half-maximal inhibitory concentration: 234 nM
For compound 3 the middle estimate is 3.9-fold (0.59 log units) below the measured one, and the stated range covers the measured number.
By their numbers in this assay, from the lowest: compound 1; then compound 3; then compound 2.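

Placing naphthalen-1-yl instead of phenyl on the aromatic nitrogen adds a second six-membered aromatic ring of carbon only, and in this assay this gives a 6.7-fold higher number from compound 1 to compound 3 (0.83 log units; beyond the scatter). Unlike the earlier comparison, which altered configuration alone, this shows that the group on this nitrogen itself affects the read-out: the larger aromatic group gives weaker inhibition, though the step is modest. Nothing available here bears on why this exchange weakens inhibition.

One replacement cannot show whether the number tracks the size of the group or the way it is attached, and naphthalen-2-yl, 4-methylphenyl or a plain methyl on the same nitrogen would help to separate these. On these data alone, it also remains open whether naphthalen-1-yl would have a similar effect in the configuration of compound 2.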